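The compounds below may be only part of what the source reports. "The series", "measured", "known", "first", "only" and "open" are said of these compounds alone.

Measured compounds:
compound 1, `Cn1ncc(Cl)c1-c1cc(C(=O)N[C@@H]2CN[C@H](CCO)C[C@H]2c2ccc(F)c(F)c2)oc1Cl`: 60 nM
compound 2, `Cn1ncc(Cl)c1-c1cc(C(=O)N[C@@H]2CN[C@H](CC(=O)O)C[C@H]2c2ccc(Cl)c(Cl)c2)oc1Cl`: 640 nM
compound 3, `CNC(=O)C[C@@H]1C[C@@H](c2ccc(Cl)c(Cl)c2)[C@H](NC(=O)c2cc(-c3c(Cl)cnn3C)c(Cl)o2)CN1`: 40 nM

All three were tested in a functional assay on LNCaP cells (Homo sapiens) for antiproliferative activity; on this read-out lower numbers stand for stronger inhibition and higher numbers for weaker inhibition. Compound 1 stands second highest of the three numbers; its nearest neighbour is compound 3, whose number lies within the scatter of it, and its furthest is compound 2, a gap well beyond the scatter. The unmeasured compound 4, `Cn1ncc(Cl)c1-c1cc(C(=O)N[C@@H]2CN[C@H](CCNS(C)(=O)=O)C[C@H]2c2ccc(F)c(F)c2)oc1Cl`, is compound 1 with a single change: methanesulfonamido in place of hydroxy on a saturated chain carbon, two bonds along the chain from a saturated ring carbon. Within the data shown here, only one measured step is available for comparison: a 16-fold lower number from compound 2 to compound 3 (1.20 log units; beyond the scatter). That step exchanged a hydroxy for a methylamino on a carbonyl carbon, a different place from the saturated chain carbon changed here, so it bears on the present step only loosely; what it shows is that the group at the end of this side chain can move the number a great deal. Compound 3, which carries the methylamino on a carbonyl carbon rather than the hydroxy of compound 1, sits within the scatter of compound 1, so a hydroxy replaced by another group with no net charge is expected to leave the number close to where it is. For compound 4 the expected step is a 1.2-fold lower number from compound 1 to compound 4 (0.08 log units; within the scatter), not beyond the scatter. Compound 4 is therefore estimated at 50 nM, with a range from 20 nM to 140 nM.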

Compound 4, half-maximal inhibitory concentration: 50 nM
The estimate for compound 4 equals the measured number at the digits printed; low and high end bracket the measured number.
By their numbers in this assay, from the lowest: compounds 3, 4 and 1 (each within the scatter of the next); then compound 2.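

In this assay, exchanging hydroxy for methanesulfonamido on the saturated chain carbon gives a 1.2-fold lower number from compound 1 to compound 4 (0.08 log units; within the scatter), so this read-out does not separate the two compounds. Compound 1 and compound 4 differ in this one place, and the pair shows that the number stays within the scatter when 1 heavy atom gives way to 5 heavy atoms, with 2 double bonds added and no net charge on either group. This is a different finding from the large step at the carbonyl carbon between compound 2 and compound 3, and nothing available here explains why the larger group leaves the number within the scatter.

The compounds shown leave open how a primary amine at the end of this chain would read, and whether a longer chain, such as 3-(methanesulfonamido)propyl, would stay within the scatter of compound 1. From the compounds shown here alone, it also remains open whether the same exchange would read alike with the two chlorines of compound 3 in place of the two fluorines of compound 1.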